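Replacing the pyrazolyl group on the amide nitrogen of compound 3

The source may report more compounds than this note shows. Statements on the series, on what has been measured and on what is new or still open speak of the compounds shown alone.

The measured set is compound 1 `Cn1ccc2ccc(-c3cc(Nc4ccccc4S(N)(=O)=O)cc4nccnc34)cc21`, compound 2 `Cn1ccc2ccc(-c3cc(Nc4ccccc4S(=O)(=O)N4CCOCC4)cc4nccnc34)cc21` and compound 3 `Cn1cc(NC(=O)c2ccncc2Nc2cc(-c3ccc4ccn(C)c4c3)c3nccnc3c2)cn1`. In an assay for inhibition of 6-phosphofructo-2-kinase/fructose-2,6-bisphosphatase 3 (Homo sapiens), read by ADP-Glo, with a stated time of 2 h (on this read-out lower numbers stand for stronger inhibition and higher numbers for weaker inhibition), compound 1 gives 265 nM, compound 2 gives 36 nM and compound 3 gives 33 nM. Compound 3 holds the lowest of the three numbers, but its gap to compound 2 lies within the scatter; only compound 1 stands beyond it. For the measured compounds named here, the single one-place step, a 7.4-fold lower number from compound 1 to compound 2 (0.87 log units; beyond the scatter), concerns another position and another pair of groups. Compound 4 `CC(=O)N1CC(CNC(=O)c2ccncc2Nc2cc(-c3ccc4ccn(C)c4c3)c3nccnc3c2)C1` differs from compound 3 in one place: (1-acetylazetidin-3-yl)methyl in place of 1-methyl-1H-pyrazol-4-yl on an amide-type nitrogen. Going by the values given here, no measured step covers such a change, so direction is open; a step near the scatter, or a modest rise, is expected, a 2.0-fold higher number from compound 3 to compound 4 (0.29 log units; within the scatter). Compound 4 is estimated at 65 nM in this assay, within 20 nM to 250 nM.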

Compound 4, half-maximal inhibitory concentration: 137 nM
Compound 4: middle estimate off by 2.1-fold (0.32 log units), on the low side; measured number inside the range.
By their numbers in this assay, from the lowest: compounds 3 and 2 (each within the scatter of the next); then compounds 4 and 1 (each within the scatter of the next).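

For the compounds shown here, this position on an amide-type nitrogen responds to its group in this assay, as (1-acetylazetidin-3-yl)methyl in place of 1-methyl-1H-pyrazol-4-yl gives a 4.2-fold higher number from compound 3 to compound 4 (0.62 log units; beyond the scatter) as the first measured change here. The swap exchanges a five-membered aromatic ring for a four-membered non-aromatic ring and also alters the heavy-atom and acceptor counts, and this single step does not separate those differences. Nothing available gives a reason for the step.

Open, going by these compounds, is whether a phenyl or a 2-(morpholin-4-yl)ethyl group on the same nitrogen would read nearer compound 3 or compound 4.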